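Swapping chloro for methoxy on an adenosine receptor ligand with a low inhibition read-out

The source may hold more compounds than are shown below. What is called first, only, known or untested is meant among the compounds shown, and "the series" means these compounds.

Measured so far:
compound 1, `Cc1csc(N)c1C(=O)c1ccc(Cl)cc1`, gives 1%
compound 2, `CC(C)(C)Cc1c(-c2ccc(Cl)cc2)sc(N)c1C(=O)c1ccc(Cl)cc1`, gives 1%

Both compounds were tested in an assay on CHO cells for displacement of a labelled ligand from adenosine receptor A3 (Homo sapiens), read by scintillation counting, tested at 10 uM; on this read-out higher numbers stand for more inhibition at the one concentration tested (going by the name of the read-out) and lower numbers for less inhibition. Compound 1 gives 1%, and compound 2 gives 1%, so the two stand level at the digits shown; the larger compound 2, with its extra substituents on the shared core, is no different from compound 1 within the scatter of this kind of measurement.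

Compound 3 is `COc1ccc(-c2sc(N)c(C(=O)c3ccc(Cl)cc3)c2CC(C)(C)C)cc1`. It differs from compound 2 in one place: methoxy in place of chloro on an aromatic carbon. Within the data shown here, no step between two measured compounds involves this change, so nothing measured here shows what it does to the read-out.

What is known is that compound 2 sits at the bottom of the scale in this assay, where small differences cannot be told apart. On that basis, compound 3 is expected to stay at the same level, with the step of a number 2 percentage points higher from compound 2 to compound 3 (within the scatter) estimated to lie within the scatter. The estimate for compound 3 in this assay is 3%, with a range from -8% to 15%.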

Compound 3, a percentage reported as inhibition, at one concentration (the size of the read-out at that concentration, not a potency): 2%
For compound 3 the middle estimate is 1 percentage points above the measured one; the measured number falls inside the stated range.
By their numbers in this assay, from the lowest: compounds 1, 2 and 3 (each within the scatter of the next).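

Among these compounds, the change from 4-chlorophenyl to 4-methoxyphenyl comes out in this assay as a number 1 percentage points higher from compound 2 to compound 3 (within the scatter) and so gives the first direct reading for this position, where the earlier compounds offered no such step. Here chloro, with 1 heavy atom, gives way to methoxy, with 2 heavy atoms and 1 hydrogen-bond acceptor, and the read-out does not separate the two compounds, so this exchange leaves compound 3 at the bottom of the scale alongside compound 2. Nothing available accounts for this flat result, and a read-out this close to the floor cannot show whether the group at this position matters at all.

As far as these compounds go, it remains open whether an amine or a carboxylic acid at the same place on the ring would raise the inhibition clearly above the scatter. Also open, from the compounds shown here alone, is whether methoxy and chloro would still read alike on a related compound that shows clear inhibition, since a difference between them could stay hidden when all the values lie this low.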